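A few compounds are considered here, and "the series" means these few. Any claim that something is new, unique, unknown or untested is made for them only; others in the source may bear on it.

Compound 3 `Oc1cccc(-c2cc(-c3ccc(OC(F)(F)F)cc3)cc(-c3cccc(O)c3)n2)c1` carries two 3-hydroxyphenyl groups on its shared core. In a functional assay on HCT-15 cells (Homo sapiens) for inhibition (a lower number here means a stronger inhibitor, a higher number a weaker inhibitor), compound 3 reaches only a limit, > 50000 nM (the limit of > 50000 nM in this assay, at which 1 of the 3 values shown sits). Compound 2 `Oc1cccc(-c2cc(-c3ccc(OC(F)(F)F)cc3)cc(-c3ccccc3O)n2)c1` gives 9410 nM in this assay, and compound 1 `Oc1ccc(-c2cc(-c3ccc(C(F)(F)F)cc3)cc(-c3cccc(O)c3)n2)cc1` gives 6440 nM. For the measured compounds named here, the one measured step that touches this part of the molecule, an at least 5.3-fold higher number from compound 2 to compound 3 (0.72 log units; beyond the scatter), shows that exchanging a hydroxyphenyl isomer can cost a good deal of inhibition. Compound 4 `Oc1ccc(-c2cc(-c3ccc(OC(F)(F)F)cc3)cc(-c3cccc(O)c3)n2)cc1` makes a related exchange in the other direction: 4-hydroxyphenyl in place of 3-hydroxyphenyl on an aromatic carbon. Going by the values given here, no measured step covers this exact change. Because compound 1, which also carries a 4-hydroxyphenyl, gives 6440 nM, compound 4 is expected to show an at least 3.3-fold lower number from compound 3 to compound 4 (0.52 log units; beyond the scatter). Compound 4 is estimated at 15000 nM, within a range from 5000 nM to 50000 nM.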

Compound 4, half-maximal inhibitory concentration: 1380 nM
Compound 4: middle estimate off by 11-fold (1.04 log units), on the high side; the measured number lies below the stated range.
By their numbers in this assay, from the lowest: compound 4; then compounds 1 and 2 (each within the scatter of the next). At a limit, above all of these: compound 3.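

At this position, next to the ring nitrogen, 4-hydroxyphenyl outperforms both 3-hydroxyphenyl, with an at least 36-fold lower number from compound 3 to compound 4 (1.55 log units; beyond the scatter), and 2-hydroxyphenyl, with a 6.8-fold lower number from compound 2 to compound 4 (0.83 log units; beyond the scatter), so where the hydroxyl sits on this ring matters greatly. The first of these steps is only a minimum because compound 3 stands at a limit: the limit of > 50000 nM in this assay, at which 1 of the 4 values shown sits.

Trifluoromethoxy in place of trifluoromethyl also gives a gain, with a 4.7-fold lower number from compound 1 to compound 4 (0.67 log units; beyond the scatter).

On these data alone, whether a 4-aminophenyl or 4-methoxyphenyl group at this position would retain this inhibition remains open. So does the effect of a second 4-hydroxyphenyl in place of the remaining 3-hydroxyphenyl.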